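Swapping a fluoro for trifluoromethoxy on the amide ring

This account rests on a few compounds, and the source may have more. Where it says the series, first, only, none or still open, it means among the compounds named here.

Compound 3 `O=C(O)COC(=O)N(C1CC1)[C@H]1c2ccccc2N(C(=O)c2ccc(F)cc2)[C@H]2CC[C@H]21` gives 2 nM in a functional assay on cells for antagonist activity at prostaglandin D2 receptor 2 (Homo sapiens), read by ELISA, chemiluminescence and cAMP accumulation, with stated times of 10 min and 60 min; a higher number here means a weaker inhibitor, a lower number a stronger inhibitor. Among the three measured compounds it stands second highest: compound 2 `O=C(O)COC(=O)N(C1CC1)[C@H]1c2ccccc2N(C(=O)c2cccc(F)c2)[C@H]2CC[C@H]21` gives 0.8 nM, and compound 1 `O=C(O)CCC(=O)N(C1CC1)[C@H]1c2ccccc2N(C(=O)c2ccc(OC(F)(F)F)cc2)[C@H]2CC[C@H]21` gives 7 nM. Within the data shown here, the only measured single-point step, a 2.5-fold higher number from compound 2 to compound 3 (0.40 log units; beyond the scatter), concerns where the fluorine sits on that ring and so does not speak to the change at hand.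

Compound 4 `O=C(O)COC(=O)N(C1CC1)[C@H]1c2ccccc2N(C(=O)c2ccc(OC(F)(F)F)cc2)[C@H]2CC[C@H]21` differs from compound 3 in one place: trifluoromethoxy in place of fluoro on an aromatic carbon. Among the measured compounds shown here, compound 1 carries the same trifluoromethoxy group on the same ring, but it also has a different chain linking the acid to the nitrogen, so its values beside those of compound 3 show only that the two compounds differ by an amount beyond the scatter, without separating the two changes. For the measured compounds named here, no measured step isolates the fluoro-to-trifluoromethoxy swap itself.

Going by the values given here, with no direct precedent, the estimate for compound 4 leans on compound 1 giving 7 nM and on compound 3 giving 2 nM, and is expected to sit in the range they bracket. The expected step is a 2.0-fold higher number from compound 3 to compound 4 (0.30 log units; within the scatter), a mild weakening. Compound 4 is therefore estimated at 4 nM, with a plausible range from 1.2 nM to 13 nM.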

Compound 4, half-maximal inhibitory concentration: 0.9 nM
Compound 4: middle estimate off by 4.4-fold (0.65 log units), on the high side; measured number outside the range, below it.
By their numbers in this assay, from the lowest: compounds 2 and 4 (each within the scatter of the next); then compound 3; then compound 1.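

On this aromatic carbon, para to a large group, trifluoromethoxy does not cost activity in this assay: replacing fluoro gives a 2.2-fold lower number from compound 3 to compound 4 (0.35 log units; beyond the scatter), a modest gain. The new pair involving compound 1 also separates two changes that were tangled before. The trifluoromethoxy ring stays fixed while carboxymethoxy replaces 2-carboxyethyl, giving a 7.8-fold lower number from compound 1 to compound 4 (0.89 log units; beyond the scatter), so the higher number of compound 1 goes with its chain and not with its ring substituent. Against the best of the fluoro compounds, the result is a 1.1-fold higher number from compound 2 to compound 4 (0.05 log units; within the scatter), which lies within the scatter, so 4-(trifluoromethoxy)phenyl and 3-fluorophenyl cannot be told apart in this assay.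

Still open is whether a methoxy, a trifluoromethyl or a chlorine on the same aromatic carbon would match trifluoromethoxy, and whether the gain over fluoro would also appear with the 2-carboxyethyl chain, where no fluoro partner is shown. Nothing available on these compounds accounts for the size or direction of these steps.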